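The source may hold more compounds than are shown below. What is called first, only, known or untested is meant among the compounds shown, and "the series" means these compounds.

Compound 1 `CC(C)N1C(=O)NC2(CC2c2ccc3cccc(OCc4ccccc4)c3n2)C1=O` is the reference point of this small set. In a functional assay on the whole organism (strain Kunming) with Mus musculus as the target, with a stated time of 0.5 h (a higher number here means that more compound is needed for the effect, a lower number that less compound is needed), compound 1 gives 100 mg/kg. Compound 2 `CCC(CO)N1C(=O)NC2(CC2c2ccc3cccc(OCc4ccccc4)c3n2)C1=O` carries a 1-(hydroxymethyl)propyl group in place of the isopropyl on an amide-type nitrogen in a ring, and in this assay compound 2 gives 100 mg/kg. The step of no change at the digits printed from compound 1 to compound 2 (within the scatter) shows that this exchange on the ring nitrogen left the minimum effective dose where it was. On the numbers available, compound 2 therefore stands level with compound 1, with no separation beyond the scatter.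

Compound 3 `O=C1NC2(CC2c2ccc3cccc(OCc4ccccc4)c3n2)C(=O)N1Cc1ccccc1` is the next member and has not yet been measured. Its difference from compound 2 is benzyl in place of 1-(hydroxymethyl)propyl on an amide-type nitrogen in a ring. Among the compounds with values here, the only step that bears on this position is the one from compound 1 to compound 2, which was flat, and it offers no guidance on a benzyl group at this nitrogen. The expected step of no change at the digits printed from compound 2 to compound 3 (within the scatter) is therefore set at none beyond the scatter, with the range widened to reflect the lack of a comparable substituent. For compound 3 in this assay the estimate is 100 mg/kg, expected between 30 mg/kg and 300 mg/kg.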

Compound 3, minimum effective dose: 300 mg/kg
Beside the measured number, compound 3's estimate is 3.0-fold (0.48 log units) below it, within the range that was stated.
By their numbers in this assay, from the lowest: compounds 1 and 2 (each within the scatter of the next); then compound 3.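

In this assay, this nitrogen proved not to be indifferent to its substituent: benzyl in place of 1-(hydroxymethyl)propyl gave a 3.0-fold higher number from compound 2 to compound 3 (0.48 log units; beyond the scatter) in this set, and benzyl in place of isopropyl gave a 3.0-fold higher number from compound 1 to compound 3 (0.48 log units; beyond the scatter) in the same direction. Within the data shown here, the two open-chain groups had stood level, so this is the first exchange at this place to move the minimum effective dose, and it moved towards more compound being needed for the effect. No measurement in hand accounts for this rise.

The compounds shown leave open whether the rise belongs to the six-membered aromatic ring itself or to the benzyl group as a whole, as neither a cyclohexylmethyl group nor a longer phenylethyl chain stands among them at this nitrogen. Also open, from the compounds shown here alone, is how a chain ending in an amine or a carboxylic acid would read here, and whether any group at this place could bring the number below the level shared by compound 1 and compound 2.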